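This account rests on a few compounds, and the source may have more. Where it says the series, first, only, none or still open, it means among the compounds named here.

Measured compounds:

compound 1, `CCCCCCCCNc1nccnc1C(=O)NCc1ccccc1`, 100000 nM
compound 2, `CCCCCCNc1nccnc1C(=O)NCc1ccccc1`, 100000 nM

Working notes on the series. Both compounds share one core and differ only in the length of the saturated chain on the nitrogen of the aromatic ring. Going by the values given here, the one measured step, no change at the digits printed from compound 1 to compound 2 (within the scatter), shows that shortening the chain leaves the read-out where it was. Compound 2 therefore stands level with compound 1 in an ADME assay on MDCK cells (Canis lupus familiaris) for cytotoxicity, read by microscopy, with a stated time of 6 days (a lower number here means that less compound is tolerated, a higher number that more compound is tolerated), with no separation beyond the scatter at the digits given.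

Compound 3, `CCCCCCCNc1nccnc1C(=O)NCc1ccccc1`, is the chain length between the two. The change from compound 2 is methyl in place of hydrogen on a saturated chain carbon, six bonds along the chain from a nitrogen on an aromatic ring. Among the compounds with values here, the only step that bears on it is the one between the neighbouring chain lengths, which was flat, so the expectation for compound 3 in this assay is no movement beyond the scatter, no change at the digits printed from compound 2 to compound 3 (within the scatter). Compound 3 is estimated at 100000 nM, in the range 50000 nM to 200000 nM.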

Compound 3, minimum cytotoxic concentration: 100000 nM
Estimate against measurement, compound 3: no gap at the digits printed; the range from low to high includes it.
By their numbers in this assay, from the lowest: compounds 1, 2 and 3 (each within the scatter of the next).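

In this assay, the change of methyl in place of hydrogen on a saturated chain carbon, six bonds along the chain from a nitrogen on an aromatic ring, reads as no change at the digits printed from compound 2 to compound 3 (within the scatter) and the change of hydrogen in place of methyl, seven bonds along the chain, reads as no change at the digits printed from compound 1 to compound 3 (within the scatter) on the same scale. The flat reading seen earlier for the larger swap of ethyl for hydrogen therefore also holds for each single-carbon change among these three chain lengths. The available data offer no measured explanation for this flatness.

Still open, as far as these compounds go, is whether the read-out stays level with a butyl chain or a longer chain than that of compound 1. Also open, from the compounds shown here alone, is the effect of an amine or a carboxylic acid at the end of the chain, since all three compounds carry unsubstituted saturated chains.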